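The source may hold more compounds than are shown below. What is called first, only, known or untested is meant among the compounds shown, and "the series" means these compounds.

Measured in a functional assay on Ramos cells (Homo sapiens) for antiproliferative activity, read by CCK-8 assay, with a stated time of 48 h; a lower number here means a stronger inhibitor, a higher number a weaker inhibitor:
Compound 1 `C=CC(=O)Nc1cccc(-n2cnc3cnc(Nc4ccc(N5CCN(C)CC5)cc4)nc32)c1`: 8220 nM
Compound 2 `C=CC(=O)Nc1cccc(-n2cnc3cnc(Nc4ccc(OC)cc4)nc32)c1`: > 40000 nM, which is a limit and not a number

Compound 2 offers no number, only (the limit of > 40000 nM in this assay, at which 1 of the 2 values shown sits). Compound 3 `C=CC(=O)Nc1cccc(-n2cnc3cnc(Nc4ccc(N5CCN(S(C)(=O)=O)CC5)cc4)nc32)c1` has 4-(methylsulfonyl)piperazin-1-yl in place of methoxy on an aromatic carbon. Within the data shown here, one measured step bears on this change, an at least 4.8-fold higher number from compound 1 to compound 2 (0.68 log units; beyond the scatter), where methoxy replaced 4-methylpiperazin-1-yl. The change to compound 3 runs the opposite way, though with a different piperazinyl group, so a modest move to a lower number is expected in this assay. The expected step is an at least 2.6-fold lower number from compound 2 to compound 3 (0.42 log units; beyond the scatter). For compound 3 the estimate is 15000 nM, with an expected range of 6000 nM to 40000 nM.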

Compound 3, half-maximal inhibitory concentration: > 40000 nM
Compound 3 ended at the assay's limit (the forecaster's own chance of this, stated with the estimate: 30%); middle value at least 2.6-fold (0.42 log units) from the limit.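

In this assay, methylsulfonyl in place of methyl on an amine nitrogen in a ring gives an at least 4.8-fold higher number from compound 1 to compound 3 (0.68 log units; beyond the scatter). A piperazinyl group at this place therefore does not by itself keep the value of compound 1; the group on the ring nitrogen matters. The step between compound 2 and compound 3 cannot be read, since each rests on a limit and not a number: the limit of > 40000 nM in this assay, at which 2 of the 3 values shown sit.

Going by these compounds, whether a free piperazin-1-yl, a 4-ethylpiperazin-1-yl or a morpholine ring would stay near compound 1 remains open. So does how far compound 2 and compound 3 lie past their limit.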